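Adding a Third Methoxy Group to Compound 2

The compounds below may be only part of what the source reports. "The series", "measured", "known", "first", "only" and "open" are said of these compounds alone.

Of the compounds shown here, three sharing one core have been measured in an ADME assay on HPLF cells (Homo sapiens) for cytotoxicity, with a stated time of 48 h; on this read-out lower numbers stand for higher toxicity in this test and higher numbers for lower toxicity in this test. Compound 1 `COc1ccc(/C=C/C(=O)c2c(C)[n+]([O-])c3ccccc3[n+]2[O-])cc1` gives 93000 nM. Compound 2 `COc1ccc(/C=C/C(=O)c2c(C)[n+]([O-])c3ccccc3[n+]2[O-])cc1OC` gives 156000 nM, the highest of the three numbers, and compound 3 `Cc1ccc(/C=C/C(=O)c2c(C)[n+]([O-])c3ccccc3[n+]2[O-])cc1` gives 23000 nM. The step of a 1.7-fold higher number from compound 1 to compound 2 (0.22 log units; within the scatter) came with a methoxy in place of hydrogen on an aromatic carbon, whereas the step of a 4.0-fold lower number from compound 1 to compound 3 (0.61 log units; beyond the scatter) came with methyl in place of methoxy on an aromatic carbon.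

Compound 4 `COc1cc(/C=C/C(=O)c2c(C)[n+]([O-])c3ccccc3[n+]2[O-])cc(OC)c1OC` has not yet been measured. Relative to compound 2 the change is methoxy in place of hydrogen on an aromatic carbon. Among the compounds with values here, the only measured step of the same kind, a 1.7-fold higher number from compound 1 to compound 2 (0.22 log units; within the scatter), stayed within the scatter, so a further methoxy is expected to move this assay little, if at all, with no direction beyond the scatter predicted. On that basis compound 4 is expected to give 170000 nM, within a range from 75000 nM to 380000 nM. The estimated step is therefore a 1.1-fold higher number from compound 2 to compound 4 (0.04 log units; within the scatter), a small one.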

Compound 4, half-maximal cytotoxic concentration: 33000 nM
For compound 4 the middle estimate is 5.2-fold (0.71 log units) above the measured one, outside the stated range (below it).
By their numbers in this assay, from the lowest: compounds 3 and 4 (each within the scatter of the next); then compounds 1 and 2 (each within the scatter of the next).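

Placing a methoxy in place of hydrogen on an aromatic carbon does not have one fixed effect in this series: the same swap that stayed within the scatter earlier now gives a clear fall in the number in this assay (a 4.7-fold lower number from compound 2 to compound 4 (0.67 log units; beyond the scatter)), meaning higher toxicity in this test. At this position, ortho to a methoxy group and meta to a large group, the added methoxy matters, so the outcome of this change depends on where it occurs or on what the ring already carries. Nothing available here explains this shift.

The compounds shown leave open whether a methoxy at this position would have the same effect without the neighbouring methoxy groups. They also leave open how a hydroxyl group or an amine at this position would behave.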